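Extending a methylsulfonyl to acetylsulfamoyl on the aryl ring

A few compounds are considered here, and "the series" means these few. Any claim that something is new, unique, unknown or untested is made for them only; others in the source may bear on it.

Measured so far:
Compound 1, `CCCS(=O)(=O)Nc1ccc(F)c(C(=O)c2n[nH]c3ncc(-c4ccc(O)cc4)cc23)c1F`, gives 0.75% in an assay for binding affinity to dual specificity mitogen-activated protein kinase kinase 4 (Homo sapiens), read by KINOMEscan, tested at 100 nM; a higher number here means a weaker effect of the compound at the concentration tested, a lower number a stronger effect.
Compound 2, `CCCS(=O)(=O)Nc1ccc(F)c(C(=O)c2n[nH]c3ncc(-c4ccc(C(C)(C)C)cc4)cc23)c1F`, gives 46% in this assay.
Compound 3, `CCCS(=O)(=O)Nc1ccc(F)c(C(=O)c2n[nH]c3ncc(-c4ccc(S(C)(=O)=O)cc4)cc23)c1F`, gives 1.5% in this assay.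

Compound 3 stands second highest of the three; its nearest neighbour is compound 1, a step of a number 0.8 percentage points higher from compound 1 to compound 3 (within the scatter), within the scatter, while compound 2 lies far off, with a number 44.5 percentage points lower from compound 2 to compound 3 (beyond the scatter). Compound 4, `CCCS(=O)(=O)Nc1ccc(F)c(C(=O)c2n[nH]c3ncc(-c4ccc(S(=O)(=O)NC(C)=O)cc4)cc23)c1F`, carries acetamido in place of methyl on a sulfonyl sulfur. Going by the values given here, no measured step touches the sulfonyl group itself; the only related steps swap the whole group on the aromatic carbon, and the one reaching compound 3 from compound 1 was small. Compound 4 is therefore expected to show a number 1.5 percentage points higher from compound 3 to compound 4 (within the scatter), no move beyond the scatter, with an estimated 3%, ranging from 0.5% to 20%.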

Compound 4, a percentage reported as activity, at one concentration (the size of the read-out at that concentration, not a potency): 0.35%
The estimate for compound 4 lay 2.7 percentage points above the measured number, and the stated range ends above it.
By their numbers in this assay, from the lowest: compounds 4, 1 and 3 (each within the scatter of the next); then compound 2.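

In this assay the swap of methyl for acetamido on a sulfonyl sulfur gives a number 1.2 percentage points lower from compound 3 to compound 4 (within the scatter) and the swap of hydroxy for acetylsulfamoyl gives a number 0.4 percentage points lower from compound 1 to compound 4 (within the scatter) so this position tolerates the extended group as well as the smaller ones. Compound 2 remains the one apart, with a number 45.7 percentage points lower from compound 2 to compound 4 (beyond the scatter) for the swap of tert-butyl for acetylsulfamoyl. Nothing measured here explains these results.

From the compounds shown here alone, whether a carboxylic acid, an amine or a longer chain on the sulfonyl nitrogen would hold this level stays open.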